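This account rests on a few compounds, and the source may have more. Where it says the series, first, only, none or still open, it means among the compounds named here.

Working notes on the series, read in an ADME assay on microsomes from liver (Mus musculus) for pharmacokinetics, read by LC-MS, using NADPH, with stated times of 5 min, 15 min and 30 min, tested at 10 uM; on this read-out higher numbers stand for fast clearance and lower numbers for slow clearance. Compound 1 (`C[C@H](NC(=O)c1cccc(F)c1)c1ccc(NC(=O)N2CC(c3cccnc3)C2)cc1`) gives 60.9 mL.min-1.g-1, compound 2 (`C[C@H](NC(=O)c1ncccn1)c1ccc(NC(=O)N2CC(c3cccnc3)C2)cc1`) gives 28.9 mL.min-1.g-1, and compound 3 (`C[C@H](NC(=O)C1CCOCC1)c1ccc(NC(=O)N2CC(c3cccnc3)C2)cc1`) gives 58 mL.min-1.g-1. Compound 3 stands within the scatter of both other measured compounds, even though those two are separated by a modest step beyond it: a 2.1-fold lower number from compound 1 to compound 2 (0.32 log units; beyond the scatter).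

Compound 4 (`CCC(=O)N[C@@H](C)c1ccc(NC(=O)N2CC(c3cccnc3)C2)cc1`) differs from compound 3 at one place: ethyl in place of oxan-4-yl on a carbonyl carbon. In words, this is ethyl in place of oxan-4-yl on a carbonyl carbon.

Going by the values given here, three measured steps bear on this change, since all of them fall on the same carbonyl carbon. Alongside the modest step above, there are a 1.1-fold lower number from compound 1 to compound 3 (0.02 log units; within the scatter) and a 2.0-fold higher number from compound 2 to compound 3 (0.30 log units; within the scatter). Both steps that end at compound 3 stay within the scatter. All three measured compounds carry a ring at this place, so ethyl, which has none, is not directly covered by these data. No step beyond the scatter is therefore expected in this assay, and no firm direction can be given. The estimate is a 1.3-fold lower number from compound 3 to compound 4 (0.11 log units; within the scatter), an expected step that remains within the scatter. For compound 4 the expected value is 45 mL.min-1.g-1, with an estimated range of 20 mL.min-1.g-1 to 90 mL.min-1.g-1.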

Compound 4, intrinsic clearance in microsomes: 31.4 mL.min-1.g-1
Compound 4: middle estimate off by 1.4-fold (0.16 log units), on the high side; low and high end bracket the measured number.
By their numbers in this assay, from the lowest: compounds 2, 4, 3 and 1 (each within the scatter of the next, the first and the last beyond it).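

In this assay, going by these compounds alone, ethyl is the first group without a ring on this carbonyl carbon, and all three of its steps stay within the scatter: a 1.8-fold lower number from compound 3 to compound 4 (0.27 log units; within the scatter) and a 1.1-fold higher number from compound 2 to compound 4 (0.04 log units; within the scatter) and also a 1.9-fold lower number from compound 1 to compound 4 (0.29 log units; within the scatter) (each as printed, none beyond it). Compound 4 thus falls within the scatter of both compound 1 and compound 2, although those two lie beyond the scatter of each other, so these four compounds show no clean split between ring-bearing groups and the ringless one, and a group of 2 heavy atoms with no hydrogen-bond acceptor gives a number in the same range as oxan-4-yl with 6 heavy atoms and 1 acceptor. No measurement is at hand that would explain why these groups read so alike on clearance.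

The compounds shown leave open whether a longer chain such as butanoyl, or a chain carrying an amine or a carboxylic acid, on this carbonyl carbon would give a step beyond the scatter from compound 4. They also leave open how much of the clearance is tied to this place at all, given that the rest of the core stays the same in all four compounds.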